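Two chlorines in place of one on the shared core

This account rests on a few compounds, and the source may have more. Where it says the series, first, only, none or still open, it means among the compounds named here.

Compound 1 `Clc1ccc(N2CCN(CCCOc3ccc4c(c3)CCC4)CC2)cc1` is measured in a functional assay on the whole organism for inhibition, with Mus musculus as the target, at a dose of 25 mg/kg by the oral route (on this read-out lower numbers stand for less inhibition and higher numbers for more inhibition at the one dose given (going by the name of the read-out)), where compound 1 gives 58%. Compound 2 `Clc1ccc(N2CCN(CCCCOc3ccc4c(c3)CCC4)CC2)cc1` shares most of this structure but differs in its core; how the two cores differ is not broken down here. In this assay compound 2 gives 33%. Compound 3 `Clc1cc(Cl)cc(N2CCN(CCCOc3ccc4c(c3)CCC4)CC2)c1` carries the change (3,5-dichlorophenyl in place of 4-chlorophenyl on an amine nitrogen in a ring), and in this assay compound 3 gives 0%, a step of a number 58 percentage points lower from compound 1 to compound 3 (beyond the scatter).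

Compound 4 `Clc1cc(Cl)cc(N2CCN(CCCCOc3ccc4c(c3)CCC4)CC2)c1` carries the same change, (3,5-dichlorophenyl in place of 4-chlorophenyl on an amine nitrogen in a ring), at the same place on the core of compound 2. Since the read-out cannot fall under nothing, the step is expected to be smaller here, about a number 30 percentage points lower from compound 2 to compound 4 (beyond the scatter), resting on compound 2 starting from 33% and on the earlier step of a number 58 percentage points lower from compound 1 to compound 3 (beyond the scatter). Compound 4 is expected to give about 3% in this assay, likely between 0% and 20%.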

Compound 4, a percentage reported as inhibition, in the whole organism at one dose (the size of the read-out at that dose, not a potency): 0%
Compound 4: the middle estimate sits 3 percentage points above what was measured, and the stated range covers the measured number.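

In this assay, the change to 3,5-dichlorophenyl again comes with a large fall, a number 33 percentage points lower from compound 2 to compound 4 (beyond the scatter), so its direction carries over from one core to the other. The size of the step does not carry over: the same change on two cores in this assay, a number 58 percentage points lower (beyond the scatter) from compound 1 to compound 3 and a number 33 percentage points lower (beyond the scatter) from compound 2 to compound 4, 25 percentage points apart, beyond the scatter of two such steps. Yet compound 3 gives 0% and compound 4 gives 0%, so both steps end where the read-out can fall no further, and the gap between them does not show that the change acts more strongly on one core.

Left open is whether the fall follows the added chlorine or the new places of the chlorines on the ring. Also open, going by these compounds, is how a phenyl ring bearing fluorine or a methoxy group instead would fare on either core.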